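This account rests on a few compounds, and the source may have more. Where it says the series, first, only, none or still open, it means among the compounds named here.

Of the compounds shown here, three have so far been measured in a functional assay on A-375 cells (Homo sapiens) for antiproliferative activity, read by trypan blue exclusion and crystal violet staining, with a stated time of 72 h; on this read-out lower numbers stand for stronger inhibition and higher numbers for weaker inhibition. Compound 1 `CCCC(=O)NC(c1ccccc1Cl)c1cc(Cl)c2cccnc2c1O` gives 100 nM, compound 2 `CCCCOc1ccnc2c(O)c(CNC(=O)C3CCCCC3)ccc12` gives 540 nM, and compound 3 `CCCCC(=O)NC(c1ccc(Cl)c(Cl)c1)c1ccc2cccnc2c1O` gives 320 nM. Among these three, compound 3 holds the second highest number: its value and that of compound 2 lie within the scatter of each other, while compound 1 shows a lower number, and that gap lies beyond the scatter. Compound 4 `CCCCC(=O)NC(c1cc(Cl)cc(Cl)c1)c1ccc2cccnc2c1O` differs from compound 3 in one place: 3,5-dichlorophenyl in place of 3,4-dichlorophenyl on a saturated chain carbon bound to an amide-type nitrogen and an aromatic carbon. Going by the values given here, no measured pair shows what such a change does here. The step of a 1.1-fold higher number from compound 3 to compound 4 (0.04 log units; within the scatter) is therefore expected to stay within the scatter, in no particular direction. Compound 4 is estimated at 350 nM, with a range from 150 nM to 800 nM.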

Compound 4, half-maximal inhibitory concentration: 90 nM
Compound 4: middle estimate off by 3.9-fold (0.59 log units), on the high side; the measured number lies below the stated range.
By their numbers in this assay, from the lowest: compounds 4 and 1 (each within the scatter of the next); then compounds 3 and 2 (each within the scatter of the next).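

Swapping 3,4-dichlorophenyl for 3,5-dichlorophenyl keeps the same atoms, yet in this assay it gives a 3.6-fold lower number from compound 3 to compound 4 (0.55 log units; beyond the scatter). At this place, on a saturated chain carbon bound to an amide-type nitrogen and an aromatic carbon, the arrangement of the two chlorines therefore matters, not only their number. No measurement at hand explains the step. From the compounds shown here alone, whether a methoxy group or a single fluorine on this ring would give a similar number remains open. So does whether the step would carry over to a longer chain on the amide.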